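The source may hold more compounds than are shown below. What is called first, only, known or untested is meant among the compounds shown, and "the series" means these compounds.

In an ADME assay for metabolic stability, read by HPLC, in simulated gastric fluid, with a stated time of 12 h, at pH 1.2 (on this read-out higher numbers stand for a longer-lived compound and lower numbers for a shorter-lived compound), compound 3 `O=C(N[C@H](CO)C(=O)O)[C@@H]1C[C@H](O)CN1` gives > 12 h, which is a limit and not a number. Compound 1 `O=C(O)[C@H](CO)NC(=O)[C@H]1C[C@H](O)CN1` gives > 12 h, also a limit. Compound 2 `O=C(O)[C@@H](CO)NC(=O)[C@H]1C[C@H](O)CN1` gives > 12 h, again a limit. Compound 4 `O=C(O)[C@H](CO)NC(=O)[C@H]1C[C@@H](O)CN1` follows from compound 3 through (the two compounds have the same atoms and bonds and differ only in configuration as drawn: 3 of 3 stereo elements differ (all stereocentres are inverted: mirror images); a stereocentre at a saturated chain carbon is drawn R in compound 3 and S in compound 4; a stereocentre at a saturated ring carbon is drawn S in compound 3 and R in compound 4; a stereocentre at a saturated ring carbon is drawn S in compound 3 and R in compound 4); the two are mirror images. Three measured steps, each a change of configuration only, bear on this: a step that the two limits leave unreadable from compound 1 to compound 2, a step that the two limits leave unreadable from compound 2 to compound 3 and a step that the two limits leave unreadable from compound 1 to compound 3. None has a readable size, and all three compounds sit at one ceiling, (the limit of > 12 h in this assay, at which 3 of the 3 values shown sit). No step beyond the scatter is therefore expected in this assay, and no direction can be assigned. The estimated step is a step that the limit leaves unreadable from compound 3 to compound 4. For compound 4, the expected half-life is 20 h, with an estimated range of 12 h to 40 h.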

Compound 4, half-life: > 12 h
Compound 4: a limit, no number; the forecaster's own chance of this, stated with the estimate: 95%; the middle value is on the limit's open side.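

In this assay compound 4 gives > 12 h, a limit and not a number. No step can be read among compound 1, compound 2, compound 3 and compound 4: the limit of > 12 h in this assay, at which 4 of the 4 values shown sit.

The compounds shown leave open whether configuration affects half-life in this assay at all.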